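Basic amine in place of acid on the chain

The source may hold more compounds than are shown below. What is called first, only, known or untested is meant among the compounds shown, and "the series" means these compounds.

Compound 1 `Cn1c(Cc2nn(C)c(=O)c3ccccc23)nnc1SCC(=O)Nc1ccc(Cl)cc1Cl` carries a methyl on the aromatic nitrogen, and in an assay on 32D cells for inhibition of interleukin-15 (Mus musculus), read by resazurin assay, with stated times of 30 min and 2.5 days, in the presence of a further agent that is not named here (on this read-out lower numbers stand for stronger inhibition and higher numbers for weaker inhibition), compound 1 gives 21100 nM. Compound 2 `Cn1c(Cc2nn(CCC(=O)O)c(=O)c3ccccc23)nnc1SCC(=O)Nc1ccc(Cl)cc1Cl` has carboxymethyl in place of hydrogen on a saturated chain carbon bound to an aromatic nitrogen. For compound 2 this assay reports only a limit, > 30000 nM, so compound 2 stands at the weak end of the numbers shown; it sits at the limit of > 30000 nM in this assay, at which 1 of the 2 values shown sits. Compound 3 `CN(C)CCCn1nc(Cc2nnc(SCC(=O)Nc3ccc(Cl)cc3Cl)n2C)c2ccccc2c1=O` differs from compound 2 by (dimethylamino)methyl in place of carboxy on a saturated chain carbon, two bonds along the chain from an aromatic nitrogen. Within the data shown here, the only measured step that bears on this change is an at least 1.4-fold higher number from compound 1 to compound 2 (0.15 log units; that floor lies within the scatter), which lies within the scatter and ends at a limit, so it sets no direction for the new compound. For compound 3 a number close to that of compound 1 is expected, an at least 1.2-fold lower number from compound 2 to compound 3 (0.07 log units; that floor lies within the scatter). Compound 3 is estimated at 25000 nM, within 8000 nM to 60000 nM, with a fair chance that this assay again reports only a limit.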

Compound 3, half-maximal inhibitory concentration: 16700 nM
Compound 3: the middle estimate sits 1.5-fold (0.18 log units) above what was measured; the measured number falls inside the stated range.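

Against the methyl, the 3-(dimethylamino)propyl chain gives a 1.3-fold lower number from compound 1 to compound 3 (0.10 log units; within the scatter) in this assay, so this place on the aromatic nitrogen carries the longer amine chain with no change beyond the scatter. Replacing 2-carboxyethyl with 3-(dimethylamino)propyl gives an at least 1.7-fold lower number from compound 2 to compound 3 (0.25 log units; that floor lies within the scatter), which is only a floor for the step. Compound 2 stands as a limit of the assay, so the size of the change from carboxylic acid to amine stays unknown: the limit of > 30000 nM in this assay, at which 1 of the 3 values shown sits.

Still open, from the compounds shown here alone, is whether a cyclic amine such as morpholine, a primary amide or a hydroxyl at the end of this chain would move the number beyond the scatter. Also open, going by these compounds, is whether a chain of another length on the same nitrogen would do so.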